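Ester in place of aryl ketone on the sulfur-bound chain

The source may hold more compounds than are shown below. What is called first, only, known or untested is meant among the compounds shown, and "the series" means these compounds.

Compound 1 `C#CCSc1nnc(CC)n1N1C(=O)c2ccccc2C1=O` in a functional assay on A549 cells (Homo sapiens) for cytotoxicity, read by MTT assay, with a stated time of 48 h (on this read-out lower numbers stand for stronger inhibition and higher numbers for weaker inhibition), gives only a limit, > 200000 nM. Compound 2 `CCc1nnc(SCC(=O)c2ccc(C)cc2)n1N1C(=O)c2ccccc2C1=O` in this assay likewise gives only a limit, > 200000 nM. The step that the two limits leave unreadable from compound 1 to compound 2 is therefore unreadable, both values sitting at the limit of > 200000 nM in this assay, at which 2 of the 2 values shown sit. Compound 3 `CCOC(=O)CSc1nnc(CC)n1N1C(=O)c2ccccc2C1=O` differs from compound 2 by ethoxy in place of 4-methylphenyl on a carbonyl carbon. For the measured compounds named here, no measured step bears on that change, and the shared core with its sulfur-bound chain is kept in compound 2 and compound 3. Compound 3 is expected to give 300000 nM, within 100000 nM to 1000000 nM, most likely again as a limit only. The step that the limit leaves unreadable from compound 2 to compound 3 is estimated as no change beyond the scatter.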

Compound 3, half-maximal inhibitory concentration: > 200000 nM
Compound 3: only a limit was reported; the forecaster's own chance of this, stated with the estimate: 85%; the middle value lies beyond the limit too.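

For the compounds shown here, compound 3 gives only a limit, so no step among compound 1, compound 2 and compound 3 can be read: the limit of > 200000 nM in this assay, at which 3 of the 3 values shown sit. What the compounds shown leave open is whether any group on the sulfur-bound chain gives a measurable value in this assay at all.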